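The source may hold more compounds than are shown below. What is called first, only, known or untested is meant among the compounds shown, and "the series" means these compounds.

Compound 1 `COc1ccc(C(c2ccccc2O)c2cccc3ccccc23)c(OC)c1OC` was tested in a functional assay on A549 cells (Homo sapiens) for inhibition, read by sulforhodamine B assay, with a stated time of 48 h (on this read-out lower numbers stand for stronger inhibition and higher numbers for weaker inhibition), and gave 13600 nM. Two companions share its core. Compound 2 `COc1ccc(C(O)(Cc2ccc(F)cc2)c2cccc3ccccc23)c(OC)c1OC` gave 5940 nM in this assay, and compound 3 `COc1ccc(/C(=N/OC(C)=O)c2cccc3ccccc23)c(OC)c1OC` gave 17200 nM. Among these three numbers compound 1 holds the second highest place: compound 3 is its nearest neighbour, and the gap between the two lies within the scatter of repeated measurements, whereas the gap down to compound 2 lies beyond it.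

Compound 4 `COc1ccc(C(OCc2ccccc2)c2cccc3ccccc23)c(OC)c1OC` has not yet been measured. It differs from compound 1 in one place (benzyloxy in place of 2-hydroxyphenyl on a saturated chain carbon bound to two aromatic carbons), so that a benzyloxy group now stands on the saturated chain carbon bound to two aromatic carbons where compound 1 carries a 2-hydroxyphenyl group. Among the compounds with values here, no measured pair in this set shows this change, so nothing can be read from it directly. The step of a 1.1-fold higher number from compound 1 to compound 4 (0.04 log units; within the scatter) that is expected for compound 4 is small, with no clear direction beyond the scatter. Compound 4 is therefore estimated at 15000 nM, within a range from 5000 nM to 45000 nM.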

Compound 4, half-maximal inhibitory concentration: 13500 nM
Estimate against measurement, compound 4: 1.1-fold (0.05 log units) above; measured number inside the range.
By their numbers in this assay, from the lowest: compound 2; then compounds 4, 1 and 3 (each within the scatter of the next).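

In this assay, within the data shown here, the first single-place step in this set gives a 1.0-fold lower number from compound 1 to compound 4 (0.00 log units; within the scatter), with benzyloxy in place of 2-hydroxyphenyl on a saturated chain carbon bound to two aromatic carbons. At this position, then, the two groups cannot be told apart by this read-out, even though benzyloxy carries no hydrogen-bond donor and 2-hydroxyphenyl carries one. Nothing at hand explains why the number holds, so this single pair records the result without giving a cause.

The compounds shown leave open whether any group at this position can move the number beyond the scatter, since both groups here contain a six-membered aromatic ring of carbon only. An amine or a carboxylic acid at the same carbon would test whether that holds without such a ring.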